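Benzyloxycarbonyl replaces methoxy beside a fixed anilide core

This account rests on a few compounds, and the source may have more. Where it says the series, first, only, none or still open, it means among the compounds named here.

Compound 1, `Nc1cc(-c2ccccc2)ccc1NC(=O)c1ccc(CNc2nccc(-c3cccnc3)n2)cc1`, in an assay on isolated protein for inhibition of protein deacetylase HDAC6 (Homo sapiens), read by fluorescence, with stated times of 3 h and 60 min (on this read-out lower numbers stand for stronger inhibition and higher numbers for weaker inhibition), gives > 20000 nM, which is a limit of the assay rather than a number. Compound 2, `COc1ccc(NC(=O)c2ccc(CNc3nccc(-c4cccnc4)n3)cc2)c(N)c1`, in this assay gives > 20000 nM, also a limit. The step that the two limits leave unreadable from compound 1 to compound 2 therefore has no readable size. Compound 2 thus stands at the limit of > 20000 nM in this assay, at which 2 of the 2 values shown sit. Compound 3, `Nc1cc(C(=O)OCc2ccccc2)ccc1NC(=O)c1ccc(CNc2nccc(-c3cccnc3)n2)cc1`, differs from compound 2 by benzyloxycarbonyl in place of methoxy on an aromatic carbon. For the measured compounds named here, with the one measured step unreadable, no step beyond the scatter can be expected in this assay. Compound 3 is estimated at 25000 nM, between 8000 nM and 60000 nM, an expected step that the limit leaves unreadable from compound 2 to compound 3.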

Compound 3, half-maximal inhibitory concentration: > 20000 nM
Compound 3: only a limit was reported; the forecaster's own chance of this, stated with the estimate: 80%; the middle value lies beyond the limit too.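

In this assay, for the compounds shown here, compound 3 gives > 20000 nM, which is a limit of the assay, so no step linking compound 1, compound 2 and compound 3 can be read. The compounds shown leave open how strongly each one inhibits, and whether phenyl, methoxy or benzyloxycarbonyl makes any difference.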